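The source may report more compounds than this note shows. Statements on the series, on what has been measured and on what is new or still open speak of the compounds shown alone.

Values in a functional assay on P388 cells (Mus musculus); a lower number here means a stronger inhibitor, a higher number a weaker inhibitor:
Compound 1 `O=C(/C=C/c1ccc(F)cc1)Oc1ccc(/C=C2\CCCCC2=O)cc1`: > 50000 nM
Compound 2 `CN(C)CC1CCC/C(=C\c2ccc(OC(=O)/C=C/c3ccc(F)cc3)cc2)C1=O`: 4550 nM
Compound 3 `Cc1ccc(C(=O)Oc2ccc(/C=C3\CCCCC3=O)cc2)cc1`: > 50000 nM

Of these three, only compound 2 has a true number, 4550 nM. Compound 1 reports only a limit, > 50000 nM. Compound 3 also reports only a limit, > 50000 nM.

Compound 4 `COc1ccc(C(=O)Oc2ccc(/C=C3\CCCC(CN(C)C)C3=O)cc2)cc1` departs from compound 2 on a carbonyl carbon, with 4-methoxyphenyl in place of 2-(4-fluorophenyl)ethenyl on a carbonyl carbon. Going by the values given here, the one measured step is an at least 10-fold lower number from compound 1 to compound 2 (1.04 log units; beyond the scatter), a large change that puts (dimethylamino)methyl in place of hydrogen on a saturated ring carbon. Compound 4 keeps that group, so this step argues for staying with compound 2 as the reference rather than falling back to the limit. It gives no size for the change on the carbonyl carbon. Compound 1 and compound 3 do not give one either, since both stop at a limit. Among the compounds with values here, with no measured step covering this change, no shift beyond the scatter is expected in this assay, and no direction can be assigned, though the uncertainty is wide. The expected step is a 1.1-fold higher number from compound 2 to compound 4 (0.04 log units; within the scatter). For compound 4 the estimated value is 5000 nM, with an expected range from 1500 nM to 20000 nM.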

Compound 4, half-maximal inhibitory concentration: 332 nM
The estimate for compound 4 lay 15-fold (1.18 log units) above the measured number; the measured number lies below the stated range.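

In this assay the group on the carbonyl carbon turns out to matter in its own right: with (dimethylamino)methyl kept in place, putting 4-methoxyphenyl in place of 2-(4-fluorophenyl)ethenyl gives a 14-fold lower number from compound 2 to compound 4 (1.14 log units; beyond the scatter). Going by these compounds alone, until now the only readable step was the one on the saturated ring carbon, an at least 10-fold lower number from compound 1 to compound 2 (1.04 log units; beyond the scatter), and this is a second large step, at a different place in the molecule. The earlier compounds could not show this, since the change in the group on the carbonyl carbon from compound 1 to compound 3 cannot be read, because both compounds end at a limit and not at a number: the limit of > 50000 nM in this assay, at which 2 of the 4 values shown sit.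

The change removes the double bond outside the aromatic rings and swaps fluorine for oxygen in one move, so the compounds shown do not tell which of these carries the step; a 4-fluorophenyl group on the carbonyl carbon would separate the two. Going by these compounds, it also remains open how a 4-chlorophenyl or a 4-dimethylaminophenyl group would fare there, and whether the step holds with a piperidinylmethyl group in place of (dimethylamino)methyl.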